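Replacing Phenylsulfonyl with Benzoyl: an Expected Growth Value

The compounds below may be only part of what the source reports. "The series", "measured", "known", "first", "only" and "open" are said of these compounds alone.

Measured compounds:
- compound 1 `COc1ccc(-c2[nH]c3ccccc3c2/C=C(\C#N)S(=O)(=O)c2ccccc2)cc1`: 1000 nM
- compound 2 `N#C/C(=C\c1c(-c2ccccc2)[nH]c2ccccc12)S(=O)(=O)c1ccccc1`: 9300 nM

Both were tested in a functional assay on HOP-62 cells (Homo sapiens) for inhibition, read by sulforhodamine B assay, with a stated time of 48 h; on this read-out lower numbers stand for stronger inhibition of growth and higher numbers for weaker inhibition of growth. For the measured compounds named here, compound 2 stands with the higher of the two numbers; the only measured step leading to it is a 9.3-fold higher number from compound 1 to compound 2 (0.97 log units; beyond the scatter), a change of hydrogen for methoxy on an aromatic carbon. Compound 3 `N#C/C(=C\c1c(-c2ccccc2)[nH]c2ccccc12)C(=O)c1ccccc1` has not been measured. It differs from compound 2 in one place: benzoyl in place of phenylsulfonyl on a double-bonded chain carbon bound to a double-bonded chain carbon and a triple-bonded carbon. Going by the values given here, no measured step bears on this kind of exchange, since the single known step concerns the methoxy group and not the group on the chain carbon. The expectation for compound 3 in this assay therefore rests on compound 2 alone, and no step beyond the scatter is expected in either direction, so the estimated step is a 1.0-fold lower number from compound 2 to compound 3 (0.01 log units; within the scatter). Compound 3 is expected to give about 9000 nM, within a wide range from 2000 nM to 40000 nM.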

Compound 3, concentration for 50% growth inhibition: 16300 nM
The estimate for compound 3 lay 1.8-fold (0.26 log units) below the measured number; low and high end bracket the measured number.
By their numbers in this assay, from the lowest: compound 1; then compounds 2 and 3 (each within the scatter of the next).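

In this assay, for the compounds shown here, the group on the double-bonded chain carbon can now be read for the first time: benzoyl in place of phenylsulfonyl gives a 1.8-fold higher number from compound 2 to compound 3 (0.24 log units; within the scatter), while the earlier step on the methoxy group, a 9.3-fold higher number from compound 1 to compound 2 (0.97 log units; beyond the scatter), lies beyond the scatter. On this read-out, and in this pair alone, the sulfur-containing group can therefore be exchanged for the carbonyl-containing one without a change that can be told from the usual scatter of repeated measurements. Nothing measured here accounts for this result.

From the compounds shown here alone, it remains open whether the exchange would read the same way on the methoxy-bearing core of compound 1. Also open, going by these compounds, is how a quite different group at this place, such as an amine or a carboxylic acid, would affect growth inhibition.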